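The source may hold more compounds than are shown below. What is called first, only, known or untested is meant among the compounds shown, and "the series" means these compounds.

Compound 1 `CCOC(=O)C1=Cc2ccccc2OC1(OCc1cn(-c2cccc(OC)c2)nn1)C(F)(F)F` was tested in a functional assay on HeLa cells (Homo sapiens) for inhibition, read by MTT assay, with a stated time of 24 h (a lower number here means a stronger inhibitor, a higher number a weaker inhibitor), and gave only a limit there, > 150000 nM, so compound 1 sits at the edge of what the test can report (the limit of > 150000 nM in this assay, at which 1 of the 2 values shown sits). A related compound, compound 2 `Cc1ccc(-c2cc(COC3(C(F)(F)F)Oc4ccccc4C=C3C(=O)O)on2)cc1`, gives 33400 nM in this assay. Compound 3 `CCOC(=O)C1=Cc2ccccc2OC1(OCc1cn(-c2ccc(F)c(Cl)c2)nn1)C(F)(F)F` differs from compound 1 in one place: 3-chloro-4-fluorophenyl in place of 3-methoxyphenyl on an aromatic nitrogen. No measured step of this kind exists among these compounds, so the change is expected to shift the reading little, if at all, beyond the usual scatter. Compound 3 is therefore estimated at 120000 nM, with a range from 30000 nM to 400000 nM. That expectation amounts to a step of an at least 1.2-fold lower number from compound 1 to compound 3 (0.09 log units; that floor lies within the scatter).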

Compound 3, half-maximal inhibitory concentration: 22700 nM
Compound 3: middle estimate off by 5.3-fold (0.72 log units), on the high side; measured number outside the range, below it.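

On the aromatic nitrogen of the five-membered ring, replacing 3-methoxyphenyl with 3-chloro-4-fluorophenyl gives an at least 6.6-fold lower number from compound 1 to compound 3 (0.82 log units; beyond the scatter) in this assay. Among the compounds shown here, this is the first sign that the group at this position can change the reading beyond the scatter. The full size of the step cannot be read, because compound 1 gives only a limit: the limit of > 150000 nM in this assay, at which 1 of the 3 values shown sits.

The compounds shown do not separate the contribution of the chlorine from that of the fluorine, or from the loss of the methoxy group. Going by these compounds, how a plain phenyl or an aminophenyl would read at this nitrogen also remains open.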